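Compound 1 to compound 4: fluoromethoxy to methoxy

The source may report more compounds than this note shows. Statements on the series, on what has been measured and on what is new or still open speak of the compounds shown alone.

In a physicochemical assay for lipophilicity, read by HPLC, in phosphate buffer, measured as octanol-water partition, with a stated time of 1 h, at pH 7.4 (on this read-out higher numbers stand for higher lipophilicity and lower numbers for lower lipophilicity), compound 1 `C[C@@]1(c2cc(NC(=O)c3cnc(OCF)cn3)ccc2F)C=C(CF)OC(N)=N1` reads 2.6 and stands within the scatter of compound 3 `C[C@@]1(c2cc(NC(=O)c3cnc(C(F)F)cn3)ccc2F)C=C(CF)OC(N)=N1` at 2.5 on the same measure. Compound 2 `CC1=C[C@@](C)(c2cc(NC(=O)c3ccc(C#N)cn3)ccc2F)N=C(N)O1` at 2.2 lies beyond the scatter below compound 1. Compound 4 `COc1cnc(C(=O)Nc2ccc(F)c([C@]3(C)C=C(CF)OC(N)=N3)c2)cn1` differs from compound 1 by hydrogen in place of fluoro on a saturated chain carbon bound to an oxygen on an aromatic ring with hydrogen in place of fluoro on a saturated chain carbon bound to an oxygen on an aromatic ring, so fluoromethoxy becomes methoxy. Going by the values given here, the one measured step at that group is a number 0.10 log units lower from compound 1 to compound 3 (within the scatter) with difluoromethyl in place of fluoromethoxy on an aromatic carbon, so a small step is expected here too. The expected step in this assay is a number 0.20 log units lower from compound 1 to compound 4 (within the scatter) and no move beyond the scatter is expected. For compound 4 the estimate is 2.4 with an expected range from 2.1 to 2.7 as its span.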

Compound 4, distribution coefficient: 2.7
For compound 4 the middle estimate is 0.30 log units below the measured one, within the range that was stated.
By their numbers in this assay, from the lowest: compounds 2, 3, 1 and 4 (each within the scatter of the next, the first and the last beyond it).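

In this assay this position takes hydrogen in place of fluoro with a number 0.10 log units higher from compound 1 to compound 4 (within the scatter) and methoxy in place of difluoromethyl with a number 0.20 log units higher from compound 3 to compound 4 (within the scatter) as the second step. Fluoromethoxy, difluoromethyl and methoxy on the shared core therefore all stand within the scatter of one another, and the earlier single step could not show this for a group without fluorine.

As far as these compounds go, whether this holds for ethoxy, trifluoromethoxy or an amine at the same place remains open. No measurement at hand accounts for these steps.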